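This account rests on a few compounds, and the source may have more. Where it says the series, first, only, none or still open, it means among the compounds named here.

Compound 1 `CCOC(=O)C(=O)Nc1ccc(N)cc1C#N`: 1 mg/kg
Compound 2 `CCOC(=O)C(=O)Nc1cc(N(C)C)ccc1C#N`: 1.9 mg/kg
Compound 3 `CCNc1cccc(NC(=O)C(=O)OCC)c1C#N`: 0.03 mg/kg

In a functional assay on the whole organism with Rattus norvegicus as the target (a lower number here means that less compound is needed, a higher number that more compound is needed for the effect), compound 3 gives 0.03 mg/kg, the lowest of the three numbers and well beyond the scatter from both others. Compound 4 `CCOC(=O)C(=O)Nc1cccc(N2CCCCC2)c1C#N` carries piperidin-1-yl in place of ethylamino on an aromatic carbon, ortho to a cyano group: piperidin-1-yl in place of ethylamino on an aromatic carbon. Among the measured compounds shown here, no two measured compounds differ in just one place, so no measured step shows what such a swap does. Compound 1 at 1 mg/kg and compound 2 at 1.9 mg/kg show that higher numbers occur in this small set, so a moderate rise is the cautious expectation. The expected change is a 6.7-fold higher number from compound 3 to compound 4 (0.82 log units; beyond the scatter). For compound 4 the estimated value is 0.2 mg/kg, with an expected range of 0.03 mg/kg to 1.5 mg/kg.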

Compound 4, dose for half-maximal effect: 2.2 mg/kg
Beside the measured number, compound 4's estimate is 11-fold (1.04 log units) below it; the whole stated range lies below it.
By their numbers in this assay, from the lowest: compound 3; then compounds 1, 2 and 4 (each within the scatter of the next, the first and the last beyond it).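

Among the compounds shown here, this is the first direct reading of a change at this position. On the aromatic carbon ortho to a cyano group, piperidin-1-yl in place of ethylamino gives, in this assay, a 73-fold higher number from compound 3 to compound 4 (1.87 log units; beyond the scatter), so this swap is far from neutral here. Nothing in the data explains the size of this step. The compounds shown leave open whether the ring or the loss of the hydrogen-bond donor counted for ethylamino matters more. Diethylamino, which has no ring and no such donor, or a longer chain such as butylamino would help separate the two.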